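The source may hold more compounds than are shown below. What is called first, only, known or untested is meant among the compounds shown, and "the series" means these compounds.

Two compounds from this study have numbers on the same read-out. Compound 1 `CCC(=O)N1CCC(c2cc(OC)ccc2N)=N1` gives 20.4% in an assay on isolated protein for inhibition of Nitric oxide synthase, inducible (Homo sapiens), with a stated time of 30 min, tested at 1 mM (on this read-out lower numbers stand for less inhibition and higher numbers for more inhibition at the one concentration tested (going by the name of the read-out)), and compound 2 `CC(=O)N1CCC(c2ccccc2N)=N1` gives 7.73% in this assay. Compound 2 thus holds the lower of the two numbers, and the gap to compound 1 lies beyond the usual scatter of such measurements. Compound 3 `CCC(=O)N1CCC(c2ccccc2N)=N1` has not yet been measured. It differs from compound 2 in one place: methyl in place of hydrogen on a saturated chain carbon bound to a carbonyl carbon. Among the measured compounds shown here, no measured pair shows this single change on its own, so its effect is unknown; compound 1 carries the same propanoyl group but also a methoxy group, so its number cannot be read as the step alone. A small rise, or none beyond the scatter, is expected. Compound 3 is expected to give 12% in this assay, between 3% and 22%, a step of a number 4.3 percentage points higher from compound 2 to compound 3 (within the scatter) from compound 2.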

Compound 3, a percentage reported as inhibition, at one concentration (the size of the read-out at that concentration, not a potency): 6.88%
Estimate against measurement, compound 3: 5.1 percentage points above, and the stated range covers the measured number.
By their numbers in this assay, from the lowest: compounds 3 and 2 (each within the scatter of the next); then compound 1.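

In this assay the swap of acetyl for propanoyl, methyl in place of hydrogen on a saturated chain carbon bound to a carbonyl carbon, reads as a number 0.9 percentage points lower from compound 2 to compound 3 (within the scatter) and so has no visible effect at this position. With propanoyl common to both compounds, hydrogen in place of methoxy on an aromatic carbon reads as a number 13.5 percentage points lower from compound 1 to compound 3 (beyond the scatter) and thereby ties the higher number of compound 1 to the methoxy group, not to the propanoyl group. Nothing available explains either step.

From the compounds shown here alone, whether a longer chain such as butanoyl would also leave the number in place remains open. So does whether a hydroxy or ethoxy group in place of methoxy would keep the higher number, and whether methoxy has the same effect alongside acetyl.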